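This account rests on a few compounds, and the source may have more. Where it says the series, first, only, none or still open, it means among the compounds named here.

Of the compounds shown here, three of a shared core have been measured in a functional assay on HCT-15 cells (Homo sapiens) for inhibition; on this read-out lower numbers stand for stronger inhibition and higher numbers for weaker inhibition. Compound 1 `Oc1cccc(-c2cc(-c3cccc(F)c3)cc(-c3cccc(O)c3)n2)c1` gives 7860 nM. Compound 2 `Oc1ccc(-c2cc(-c3ccccc3F)cc(-c3cccc(O)c3)n2)cc1` gives 5630 nM, and compound 3 `Oc1ccc(-c2cc(-c3cccc(F)c3)cc(-c3cccc(O)c3)n2)cc1` gives 3070 nM.

Compound 1 and compound 3 differ in one place: 4-hydroxyphenyl in place of 3-hydroxyphenyl on an aromatic carbon. This change made a 2.6-fold lower number from compound 1 to compound 3 (0.41 log units; beyond the scatter). Compound 2 and compound 3 also differ in one place, and there a 1.8-fold lower number from compound 2 to compound 3 (0.26 log units; within the scatter). The difference between compound 1 and compound 2 is not broken down here; their values stand within the scatter of each other.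

Compound 4 `Oc1ccc(-c2cc(-c3ccccc3F)cc(-c3ccc(O)cc3)n2)cc1` has not yet been measured. It differs from compound 2 in this way: 4-hydroxyphenyl in place of 3-hydroxyphenyl on an aromatic carbon. Within the data shown here, this is the same kind of change as the one from compound 1 to compound 3, but not the same: in compound 1 the place is meta to a 3-fluorophenyl group and meta to a 3-hydroxyphenyl group, whereas in compound 2 it is meta to a 2-fluorophenyl group and meta to a 4-hydroxyphenyl group.

Since the same kind of change gave a 2.6-fold lower number from compound 1 to compound 3 (0.41 log units; beyond the scatter), a step of about a 2.4-fold lower number from compound 2 to compound 4 (0.39 log units; beyond the scatter) is expected from compound 2 to compound 4 in this assay, starting from the value of compound 2, 5630 nM. The surroundings of the place are not identical, so the expected step carries some uncertainty.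

Compound 4 is therefore estimated at 2300 nM in this assay, with the estimate expected to fall between 1100 nM and 4800 nM.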

Compound 4, half-maximal inhibitory concentration: 8180 nM
Beside the measured number, compound 4's estimate is 3.6-fold (0.55 log units) below it, outside the stated range (above it).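

In this assay the change from 3-hydroxyphenyl to 4-hydroxyphenyl on the core of compound 2 gave a 1.5-fold higher number from compound 2 to compound 4 (0.16 log units; within the scatter) and so brought no shift that can be told from repeat scatter, whereas the same change on the core of compound 1 had given a clear drop in the number. The change therefore cannot be treated as a fixed step that travels between these two cores, and its size depends on which core carries it: the same change on two cores in this assay, a 2.6-fold lower number (0.41 log units; beyond the scatter) from compound 1 to compound 3 and a 1.5-fold higher number (0.16 log units; within the scatter) from compound 2 to compound 4, 3.7-fold (0.57 log units) apart, beyond the scatter of two such steps

This does not show which feature of the cores is responsible, since the comparison rests on one pair per core and those cores differ both in the fluorophenyl group and in the other hydroxyphenyl group, so neither the fluorine position nor the second hydroxyl can be singled out.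

The compounds shown carry only hydroxyphenyl and fluorophenyl groups, so it stays open how the change would behave on a core bearing a chlorophenyl or an unsubstituted phenyl group. From the compounds shown here alone, it also stays open whether a methoxyphenyl or an aminophenyl group in place of either hydroxyphenyl group would follow the pattern of compound 3 or that of compound 4.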